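Replacing methoxycarbonyl with trifluoromethyl in a growth-inhibition series

The compounds below may be only part of what the source reports. "The series", "measured", "known", "first", "only" and "open" are said of these compounds alone.

In a functional assay on HepG2 cells (Homo sapiens) for inhibition, read by MTT assay (on this read-out lower numbers stand for stronger inhibition of growth and higher numbers for weaker inhibition of growth), compound 1 (`COc1cc2oc(-c3cccc(NC(=O)c4ccccc4)c3)cc(=O)c2c(OC)c1OC`) gives 11700 nM. Compound 2 (`COc1cc2oc(-c3cccc(NC(=O)c4cccc(C#N)c4)c3)cc(=O)c2c(OC)c1OC`) gives 11900 nM, and the two sit close together: a 1.0-fold higher number from compound 1 to compound 2 (0.01 log units; within the scatter). Compound 3 (`COC(=O)c1ccc(C(=O)Nc2cccc(-c3cc(=O)c4c(OC)c(OC)c(OC)cc4o3)c2)cc1`) gives > 100000 nM, which is a limit of this assay and not a number. That places compound 3 at the limit of > 100000 nM in this assay, at which 1 of the 3 values shown sits.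

Compound 4 (`COc1cc2oc(-c3cccc(NC(=O)c4ccc(C(F)(F)F)cc4)c3)cc(=O)c2c(OC)c1OC`) differs from compound 3 at one place, with trifluoromethyl in place of methoxycarbonyl on an aromatic carbon, para to a large group: trifluoromethyl in place of methoxycarbonyl on an aromatic carbon.

Two measured steps lead into compound 3 and bear directly on this change. One is an at least 8.5-fold higher number from compound 1 to compound 3 (0.93 log units; beyond the scatter), and the other is an at least 8.4-fold higher number from compound 2 to compound 3 (0.92 log units; beyond the scatter). Compound 4 no longer carries the methoxycarbonyl that sets compound 3 apart, so its number is expected to fall back towards those of compound 1 and compound 2. The step of a 1.0-fold higher number from compound 1 to compound 2 (0.01 log units; within the scatter) adds some support, as compound 2 shows one added group leaving the number in place. None of the three measured compounds carries trifluoromethyl, so the expectation stays broad.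

The expected step is an at least 5.0-fold lower number from compound 3 to compound 4 (0.69 log units; beyond the scatter), towards stronger inhibition of growth.

For compound 4 the estimated value is 20000 nM, with an expected range from 6000 nM to 90000 nM.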

Compound 4, concentration for 50% growth inhibition: 61100 nM
For compound 4 the middle estimate is 3.1-fold (0.49 log units) below the measured one; the measured number falls inside the stated range.
By their numbers in this assay, from the lowest: compounds 1 and 2 (each within the scatter of the next); then compound 4. At a limit, above all of these: compound 3.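

Compound 3 sits at a limit of the assay and not at a number: the limit of > 100000 nM in this assay, at which 1 of the 4 values shown sits. Compound 4 gives a real number at the same position, and the change reads as an at least 1.6-fold lower number from compound 3 to compound 4 (0.21 log units; that floor lies within the scatter) and so leaves the true size of this step unknown. Losing the methoxycarbonyl does not bring back the earlier level, since the comparison with the unsubstituted benzamide is a 5.2-fold higher number from compound 1 to compound 4 (0.72 log units; beyond the scatter) and the comparison with the nitrile compound is a 5.1-fold higher number from compound 2 to compound 4 (0.71 log units; beyond the scatter), which shows that a group other than methoxycarbonyl on this aromatic carbon can also weaken growth inhibition, something the earlier compounds could not show.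

With only hydrogen, methoxycarbonyl and trifluoromethyl seen on this carbon, the compounds shown leave open what the two weaker compounds have in common and whether any substituent here weakens growth inhibition. As far as these compounds go, it also remains open whether a fluorine, a methoxy, an amine, a carboxylic acid or a nitrile on this same carbon would stay with compound 1 or fall towards compound 4.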